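Adding Chloro to an Inactive Amide: Compound 3 to Compound 4

A few compounds are considered here, and "the series" means these few. Any claim that something is new, unique, unknown or untested is made for them only; others in the source may bear on it.

Compound 1 `O=C(CN1CCN(c2ccccn2)CC1)Nc1cccnc1`: 2660 nM
Compound 2 `CCc1cccc(NC(=O)CN2CCN(c3ccc(Cl)cn3)CC2)c1`: "not active" (no number reported)
Compound 3 `O=C(CN1CCN(c2ccccn2)CC1)Nc1cncnc1`: "not active" (no number reported)

Among the compounds with values here, in an assay on cells for agonist activity at D(4) dopamine receptor (Homo sapiens), read by luminescence and beta-arrestin recruitment, with a stated time of 90 min (a lower number here means that less compound is needed, a higher number that more compound is needed for the effect), compound 1 gives 2660 nM, the only number in this set. Compound 2 was reported as "not active" (no number reported), and compound 3 likewise as "not active" (no number reported), so compound 3 stands with no single number, sharing that outcome with compound 2. Compound 4 `O=C(CN1CCN(c2ccc(Cl)cn2)CC1)Nc1cncnc1` arises from compound 3 by one change: chloro in place of hydrogen on an aromatic carbon. Within the data shown here, no step between measured compounds has been quantified, so no direction can be read from the data; compound 2, which also carries chloro, gave no number either. I expect no change beyond the scatter, with compound 4 most likely again reported without a number, and estimate 10000 nM (range 3000 nM to 40000 nM).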

Compound 4, half-maximal effective concentration: "not active" (no number reported)
Compound 4: no number reported, so the estimate cannot be set against anything.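

In this assay compound 3 and compound 4 were both reported as not active, without a number, so no step can be read between them, and no measurement here offers an explanation. On these data alone, what chloro in place of hydrogen does to a compound with a measurable value remains open.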